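Amide Variation on a Shared Core Toward a Fluorobenzamide

A few compounds are considered here, and "the series" means these few. Any claim that something is new, unique, unknown or untested is made for them only; others in the source may bear on it.

Compound 1, `CCC(=O)Nc1ccc(N2CCN(c3ccc(OC[C@@H]4CO[C@@](Cn5cncn5)(c5ccc(Cl)cc5Cl)O4)cc3)CC2)cc1`, gives 2550 nM in a functional assay on A549 cells (Homo sapiens) for inhibition, read by MTT assay, with a stated time of 48 h; a lower number here means a stronger inhibitor, a higher number a weaker inhibitor.
Compound 2, `O=C(CCCCc1ccccc1)Nc1ccc(N2CCN(c3ccc(OC[C@@H]4CO[C@@](Cn5cncn5)(c5ccc(Cl)cc5Cl)O4)cc3)CC2)cc1`, gives 2610 nM in this assay.
Compound 3, `O=C(CCCc1ccccc1)Nc1ccc(N2CCN(c3ccc(OC[C@@H]4CO[C@@](Cn5cncn5)(c5ccc(Cl)cc5Cl)O4)cc3)CC2)cc1`, gives 3780 nM in this assay.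

Compound 3 carries the highest number of the measured set, yet the steps leading to it, a 1.5-fold higher number from compound 1 to compound 3 (0.17 log units; within the scatter) and a 1.4-fold higher number from compound 2 to compound 3 (0.16 log units; within the scatter), both fall within the scatter, as does a 1.0-fold higher number from compound 1 to compound 2 (0.01 log units; within the scatter). Within the data shown here, on these numbers no compound can be called the stronger or the weaker inhibitor; the acyl side of the amide has so far been varied without any change beyond the scatter.

Compound 4, `O=C(Nc1ccc(N2CCN(c3ccc(OC[C@@H]4CO[C@@](Cn5cncn5)(c5ccc(Cl)cc5Cl)O4)cc3)CC2)cc1)c1cccc(F)c1`, differs from compound 3 by 3-fluorophenyl in place of 3-phenylpropyl on a carbonyl carbon. The three measured steps bear on it only indirectly: they lengthen or shorten a saturated chain on the acyl side and move a phenyl along it, whereas here an aromatic ring is placed directly on the carbonyl carbon. Among the measured compounds shown here, no measured pair exchanges a chain for an aryl at that position. Given that every acyl variation so far sat within the scatter, the step of a 1.3-fold lower number from compound 3 to compound 4 (0.10 log units; within the scatter) is expected to be no larger, with the uncertainty widened for the untested aroyl type. Compound 4 is therefore estimated at 3000 nM in this assay, with a range from 1100 nM to 8500 nM.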

Compound 4, half-maximal inhibitory concentration: 6640 nM
For compound 4 the middle estimate is 2.2-fold (0.35 log units) below the measured one, within the range that was stated.
By their numbers in this assay, from the lowest: compounds 1, 2, 3 and 4 (each within the scatter of the next, the first and the last beyond it).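

Placing 3-fluorophenyl on the carbonyl carbon produces the first steps at this position that lie beyond the scatter in this assay: modest steps in place of 4-phenylbutyl (a 2.5-fold higher number from compound 2 to compound 4 (0.41 log units; beyond the scatter)) and in place of ethyl (a 2.6-fold higher number from compound 1 to compound 4 (0.42 log units; beyond the scatter)). The exchange for 3-phenylpropyl stays within the scatter (a 1.8-fold higher number from compound 3 to compound 4 (0.24 log units; within the scatter)), so compound 3 goes against any reading that sets the aromatic ring on the carbonyl carbon apart from all the saturated chains, and the separation holds only for compound 1 and compound 2. Nothing available gives a reason for these steps.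

The compounds shown do not separate the contribution of the fluorine from that of an aromatic ring placed directly on the carbonyl carbon, a question that an unsubstituted phenyl or a 3-chlorophenyl at this position would bear on. They also leave open how this position responds to an acyl chain ending in an amine or a carboxylic acid, since every group here is built from carbon alone apart from the single fluorine.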